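Bromo for Butoxy: An Estimate for Compound 4

This account rests on a few compounds, and the source may have more. Where it says the series, first, only, none or still open, it means among the compounds named here.

Compound 1 `Cc1ncc(N2CCNCC2)cc1Cl` — 520 nM
Compound 2 `Oc1cc(N2CCCNCC2)cnc1I` — 22 nM
Compound 3 `CCCCOc1cncc(N2CCCNCCC2)c1` — 1.8 nM

Of the compounds shown here, three have been measured in an assay (strain Wistar) for binding affinity to Neuronal acetylcholine receptor; alpha4/beta2 (Rattus norvegicus); a lower number here means a stronger inhibitor, a higher number a weaker inhibitor. Compound 1 gives 520 nM, compound 2 gives 22 nM, and compound 3 gives 1.8 nM. Compound 3 therefore has the lowest number of the three; compound 2 is nearest to it, with a number beyond the scatter higher, and compound 1 is furthest, far beyond the scatter higher. No pair of these compounds differs in only one place, so no single step can be read from them.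

Compound 4 `Brc1cncc(N2CCCNCCC2)c1` has not yet been measured. It differs from compound 3 in one place: bromo in place of butoxy on an aromatic carbon. Among the measured compounds shown here, with no measured step of this kind available, the expectation rests on the value of compound 3 alone. The change is expected to cost some affinity, a moderate step toward a higher number, possibly somewhat beyond the scatter: for compound 4 the expected result in this assay is 6 nM, within a range of 1.5 nM to 30 nM. The step this estimate implies from compound 3 to compound 4 is a 3.3-fold higher number from compound 3 to compound 4 (0.52 log units; beyond the scatter).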

Compound 4, half-maximal inhibitory concentration: 2.8 nM
For compound 4 the middle estimate is 2.1-fold (0.33 log units) above the measured one; the range from low to high includes it.
By their numbers in this assay, from the lowest: compounds 3 and 4 (each within the scatter of the next); then compound 2; then compound 1.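

In this assay, replacing butoxy with bromo on this aromatic carbon, two atoms from the ring nitrogen, gives a 1.6-fold higher number from compound 3 to compound 4 (0.19 log units; within the scatter). Among the compounds shown here, this is the first single-place step, and it shows that on this core the two groups cannot be told apart in this assay, although butoxy brings 5 heavy atoms and 1 hydrogen-bond acceptor and bromo brings 1 heavy atom and no acceptor. At this position, then, neither the four carbons of the chain nor its oxygen is required for a value in the range of compound 3.

On these data alone, whether an amine, a carboxylic acid or a longer chain on the same carbon would also stay within the scatter of compound 3 remains open, as does whether the step would hold on the core of compound 1. Nothing measured alongside these values explains why the two groups match.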